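A few compounds are considered here, and "the series" means these few. Any claim that something is new, unique, unknown or untested is made for them only; others in the source may bear on it.

Measured in an assay on CHO cells for displacement of a labelled ligand from Substance-P receptor (Homo sapiens); on this read-out lower numbers stand for stronger inhibition and higher numbers for weaker inhibition:
compound 1 `Oc1n[nH]c(CN[C@H](COCc2cc(C(F)(F)F)cc(C(F)(F)F)c2)c2ccccc2)n1`: 2.4 nM
compound 2 `FC(F)(F)c1cc(COC[C@@H](NCc2nn[nH]n2)c2ccccc2)cc(C(F)(F)F)c1`: 23 nM
compound 3 `CN(Cc1nn[nH]n1)[C@H](COCc1cc(C(F)(F)F)cc(C(F)(F)F)c1)c1ccccc1`: 70 nM

Compound 3 stands highest of the three numbers in this assay: a 3.0-fold higher number from compound 2 to compound 3 (0.48 log units; beyond the scatter), and a 29-fold higher number from compound 1 to compound 3 (1.46 log units; beyond the scatter).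

Compound 4 `CCN(Cc1n[nH]c(O)n1)[C@H](COCc1cc(C(F)(F)F)cc(C(F)(F)F)c1)c1ccccc1` differs from compound 3 by ethyl((5-hydroxy-1H-1,2,4-triazol-3-yl)methyl)amino in place of ((2H-tetrazol-5-yl)methyl)(methyl)amino on a saturated chain carbon bound to an aromatic carbon and a saturated chain carbon. Within the data shown here, two measured steps bear on this. The ring exchange is the reverse of a 9.6-fold higher number from compound 1 to compound 2 (0.98 log units; beyond the scatter), so a lower number in this assay of about that size is expected from it. Among the measured compounds shown here, the ethyl in place of methyl on the amine nitrogen has no measured counterpart; the only step on that nitrogen is a 3.0-fold higher number from compound 2 to compound 3 (0.48 log units; beyond the scatter). Overall compound 4 is expected to give a lower number than compound 3, roughly an 8.8-fold lower number from compound 3 to compound 4 (0.94 log units; beyond the scatter) in this assay, with wide uncertainty from the untested ethyl. Compound 4 is estimated at 8 nM, range 2.5 nM to 30 nM.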

Compound 4, half-maximal inhibitory concentration: 0.8 nM
Estimate against measurement, compound 4: 10-fold (1.00 log units) above; measured number below the stated range.
By their numbers in this assay, from the lowest: compound 4; then compound 1; then compound 2; then compound 3.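

In this assay, ethyl on the amine nitrogen with the hydroxytriazole ring retained gives a 3.0-fold lower number from compound 1 to compound 4 (0.48 log units; beyond the scatter) and so does not repeat the rise seen with methyl on the tetrazole, a 3.0-fold higher number from compound 2 to compound 3 (0.48 log units; beyond the scatter). The combined changes give a 29-fold lower number from compound 2 to compound 4 (1.46 log units; beyond the scatter) and an 88-fold lower number from compound 3 to compound 4 (1.94 log units; beyond the scatter), so the nitrogen substituent and ring type do not read as independent contributions here. No measured evidence explains this difference.

Still open, going by these compounds, is how methyl or a longer chain such as propyl on the amine nitrogen behaves with the hydroxytriazole ring. Ethyl on the tetrazole is equally open.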